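This account rests on a few compounds, and the source may have more. Where it says the series, first, only, none or still open, it means among the compounds named here.

Compound 1 `C/C(=N/Nc1nc(-c2ccc(C#N)cc2)cs1)c1cccs1` gives 40% in an in vitro assay on BTI-TN-5B1-4 cells for inhibition of Amine oxidase [flavin-containing] A (Homo sapiens), read by Amplex Red, with a stated time of 15 min, tested at 100 uM; a higher number here means more inhibition at the concentration tested (going by the name of the read-out), a lower number less inhibition. Compound 2 `C/C(=N/Nc1nc(-c2ccc(C#N)cc2)cs1)c1cccnc1` gives 40% in this assay, and the step of no change at the digits printed from compound 1 to compound 2 (within the scatter) accompanies the change (pyridin-3-yl in place of thiophen-2-yl on a carbon with a double bond to nitrogen). Compound 3 `Fc1ccc(-c2csc(N/N=C\c3cccs3)n2)cc1` gives 40% in this assay, level with compounds 1 and 2; the difference between its core and the core of compound 1 is not broken down here. Compound 4 `Fc1ccc(-c2csc(N/N=C\c3cccnc3)n2)cc1` has not yet been measured and differs from compound 3 by pyridin-3-yl in place of thiophen-2-yl on a carbon with a double bond to nitrogen. Within the data shown here, this is the same kind of change as the one from compound 1 to compound 2, though the surroundings differ: in compound 1 the carbon also carries a saturated chain carbon, while in compound 3 its only other neighbour is the double-bonded nitrogen. Because no change at the digits printed from compound 1 to compound 2 (within the scatter) stayed within the scatter, the step of no change at the digits printed from compound 3 to compound 4 (within the scatter) is likewise expected to be small. Compound 4 is therefore estimated at 40%, expected to lie between 28% and 52%.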

Compound 4, a percentage reported as inhibition, at one concentration (the size of the read-out at that concentration, not a potency): 40%
Compound 4: middle estimate and measured number agree at the digits printed; the measured number falls inside the stated range.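

In this assay, pyridin-3-yl in place of thiophen-2-yl on a carbon with a double bond to nitrogen gives no change at the digits printed from compound 3 to compound 4 (within the scatter). Set beside the earlier step, the result carries over from one core to the other: the same change on two cores in this assay, no change at the digits printed (within the scatter) from compound 1 to compound 2 and no change at the digits printed (within the scatter) from compound 3 to compound 4, 0 percentage points apart, within the scatter of two such steps. Among these compounds, this shows only that the change left the read-out level on both cores at a single concentration; it does not show that a step of real size would carry over, or that the two cores would stay alike at any other concentration.

The compounds shown leave open how an amine or a carboxylic acid on that same carbon would read. They also leave open whether a phenyl ring there would behave like thiophen-2-yl and pyridin-3-yl.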